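Swapping a Sulfamoylphenyl for an Acetylphenyl on the Amide

The source may report more compounds than this note shows. Statements on the series, on what has been measured and on what is new or still open speak of the compounds shown alone.

Compound 1 `COc1ccc(Oc2ccc([N+](=O)[O-])cc2C(=O)Nc2ccc(S(N)(=O)=O)cc2)cc1` sets the reference: in a functional assay (Homo sapiens) for inhibition, using a membrane potential dye, in the presence of a further agent that is not named here (on this read-out lower numbers stand for stronger inhibition and higher numbers for weaker inhibition), compound 1 gives 1800 nM. Compound 2 `COc1ccc(Oc2ccc([N+](=O)[O-])cc2C(=O)Nc2ccccc2S(N)(=O)=O)cc1` bears a 2-sulfamoylphenyl on the amide nitrogen, and in this assay compound 2 gives "no significant activity" (no number reported), so no number stands for it on this read-out. Compound 3 `COc1ccc(Oc2ccc([N+](=O)[O-])cc2C(=O)Nc2ccc(C(C)=O)cc2)cc1` differs from compound 2 by 4-acetylphenyl in place of 2-sulfamoylphenyl on an amide-type nitrogen. For the measured compounds named here, no step between measured compounds is available, so the size of this change in this assay cannot be read from the data; a measurable value is expected, since compound 1 gives 1800 nM. Compound 3 is expected to give 3000 nM, within a range from 800 nM to 15000 nM.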

Compound 3, half-maximal inhibitory concentration: 8100 nM
Beside the measured number, compound 3's estimate is 2.7-fold (0.43 log units) below it; low and high end bracket the measured number.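

In this assay, acetyl in place of sulfamoyl on an aromatic carbon gives a 4.5-fold higher number from compound 1 to compound 3 (0.65 log units; beyond the scatter), so a measurable but weaker inhibition remains without the sulfamoyl group. The sulfamoyl group is therefore not required for a number on this read-out, although the step is modest. Steps to compound 2 cannot be read, since it has no number, and no evidence shown explains the change. The compounds shown leave open how an amine or a carboxylic acid would compare at the same aromatic carbon. They also leave open whether acetyl would fare differently on a 2-substituted phenyl.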